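Biaryl amide series: pyrimidine replacing pyridine

A few compounds are considered here, and "the series" means these few. Any claim that something is new, unique, unknown or untested is made for them only; others in the source may bear on it.

Of the compounds shown here, two have been measured in a functional assay on Dorsal root ganglion for antagonist activity at transient receptor potential cation channel subfamily V member 1 (Rattus norvegicus); a higher number here means a weaker inhibitor, a lower number a stronger inhibitor. Compound 1 `CC(C)(C)c1ccc(NC(=O)N2CCN(c3ccccn3)CC2)cc1` gives 150 nM in this assay. Compound 2 `CC(C)(C)c1ccc(NC(=O)c2ccc(-c3ccncc3)cc2)cc1` gives 280 nM in this assay, the higher of the two numbers; compound 1 sits a short distance from it, and that gap lies within the scatter, so the two are not distinguished by these data.

Compound 3 `CC(C)(C)c1ccc(NC(=O)c2ccc(-c3cncnc3)cc2)cc1` has not been measured. It differs from compound 2 by pyrimidin-5-yl in place of pyridin-4-yl on an aromatic carbon, a change that keeps the size of the group and adds one ring nitrogen. For the measured compounds named here, no step between measured compounds is available to calibrate such a change, so the expectation rests on compound 2 alone. Compound 3 is expected to stay close to compound 2, with a step of a 1.4-fold higher number from compound 2 to compound 3 (0.15 log units; within the scatter) that is estimated to fall inside or near the scatter, if anything toward a slightly higher number. The estimated value for compound 3 in this assay is 400 nM, within a range from 150 nM to 1100 nM.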

Compound 3, half-maximal inhibitory concentration: 10000 nM
Compound 3: the middle estimate sits 25-fold (1.40 log units) below what was measured, and the stated range ends below it.
By their numbers in this assay, from the lowest: compounds 1 and 2 (each within the scatter of the next); then compound 3.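

In this assay, the aromatic carbon para to a large group proves highly sensitive to the ring it carries: pyrimidin-5-yl in place of pyridin-4-yl gives a 36-fold higher number from compound 2 to compound 3 (1.55 log units; beyond the scatter), although the heavy-atom count stays the same. For the compounds shown here, this is the first step that isolates a single change at this position, as compound 1 and compound 2 differ in more than one place and could not show this sensitivity. Nothing measured here accounts for the size of the step.

As far as these compounds go, whether the step follows the added ring nitrogen itself or the different placement of nitrogen implied by the two group names remains open. Also open, from the compounds shown here alone, is how an unsubstituted phenyl ring, a pyridin-3-yl group or an aminopyridine on this carbon would compare in this assay.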